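The source may report more compounds than this note shows. Statements on the series, on what has been measured and on what is new or still open speak of the compounds shown alone.

Measured in a functional assay on MGC-803 cells (Homo sapiens) for antiproliferative activity, read by MTT assay, with a stated time of 48 h; a lower number here means a stronger inhibitor, a higher number a weaker inhibitor:
Compound 1 `CCCCCCCCn1cc(COC[C@@H]2OC[C@H](N)[C@@H]2O)nn1`: 70400 nM
Compound 2 `CCCCCCCCn1cc(COC[C@@H]2OC[C@H](N)[C@H]2O)nn1`: > 128000 nM

Compound 2 has no exact number here, as its > 128000 nM is a limit of the assay. Compound 3 `CCCCCCCCCCCCCCCCCCn1cc(COC[C@@H]2OC[C@H](N)[C@H]2O)nn1` has not yet been measured. It keeps the core of compound 2 and alters only the chain: decyl in place of hydrogen on a saturated chain carbon, eight bonds along the chain from an aromatic nitrogen. Going by the values given here, the one measured step is an at least 1.8-fold higher number from compound 1 to compound 2 (0.25 log units; that floor lies within the scatter). That step rests on (the fact that compounds 1 and 2 differ only in the configuration as drawn), so it does not show what a change in the chain does. Among the compounds with values here, no measured pair tests a longer chain, which leaves the expectation weak: a modest shift to a lower number in this assay, or none that can be read. Compound 3 may also be reported only as a limit. For compound 3 the expected value is 80000 nM, with an estimated range from 25000 nM to 200000 nM. The estimated change is an at least 1.6-fold lower number from compound 2 to compound 3 (0.20 log units; that floor lies within the scatter).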

Compound 3, half-maximal inhibitory concentration: 3110 nM
Compound 3: the middle estimate sits 26-fold (1.41 log units) above what was measured, and the stated range ends above it.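

In this assay, decyl in place of hydrogen on a saturated chain carbon, eight bonds along the chain from an aromatic nitrogen, gives an at least 41-fold lower number from compound 2 to compound 3 (1.61 log units; beyond the scatter), so a change at this place in the chain can move the read-out far beyond the scatter. The earlier step could not show this, as it says nothing about the chain: the fact that compounds 1 and 2 differ only in the configuration as drawn. Compound 2 is reported only as a limit, so this step gives a floor and not an exact size: the limit of > 128000 nM in this assay, at which 1 of the 3 values shown sits.

The compounds shown leave open whether a shorter addition, giving a dodecyl chain, would already bring much of this change, or whether a longer icosyl chain would go further. They also leave open whether the configuration that separates compound 1 from compound 2 still matters once the chain is this long.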